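Swapping a Piperidine for Cyclohexylamine on the Shared Core

This account rests on a few compounds, and the source may have more. Where it says the series, first, only, none or still open, it means among the compounds named here.

Measured compounds:
compound 1, `COC(CCn1cnc2c(NCc3ccc(C(=O)Nc4ccccc4N)cc3)nc(Cl)nc21)OC`, 34.2%
compound 2, `CC1CCN(c2nc(Cl)nc3c2ncn3Cc2ccc(/C=C/C(=O)Nc3ccccc3N)cc2)CC1`, 32.2%
compound 3, `Nc1ccccc1NC(=O)c1ccc(COCNc2nc(Nc3ccccc3)c3ncn(C4CCCC4)c3n2)cc1`, 66.9%

In a functional assay on HepG2 cells (Homo sapiens) for antiproliferative activity, read by CCK-8 assay, with a stated time of 72 h, tested at 8 uM (a higher number here means a stronger effect of the compound at the concentration tested, a lower number a weaker effect), compound 2 gives the lowest of the three numbers. Its nearest neighbour is compound 1, which lies within the scatter of it; compound 3 stands well beyond the scatter above both. Compound 4, `Nc1ccccc1NC(=O)/C=C/c1ccc(Cn2cnc3c(NC4CCCCC4)nc(Cl)nc32)cc1`, has not been measured. It differs from compound 2 in one place: cyclohexylamino in place of 4-methylpiperidin-1-yl on an aromatic carbon. Among the measured compounds shown here, no measured pair shows this kind of change, so its effect is unknown. The step of a number 5.8 percentage points higher from compound 2 to compound 4 (within the scatter) is expected to be small, upward if anything, and probably not beyond the scatter. For compound 4 the expected value in this assay is 38%, within a range from 22% to 55%.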

Compound 4, a percentage reported as inhibition, at one concentration (the size of the read-out at that concentration, not a potency): 42.7%
Compound 4: middle estimate off by 4.7 percentage points, on the low side; low and high end bracket the measured number.
By their numbers in this assay, from the lowest: compounds 2, 1 and 4 (each within the scatter of the next, the first and the last beyond it); then compound 3.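

In this assay, among the compounds shown here, placing cyclohexylamino instead of 4-methylpiperidin-1-yl on the aromatic carbon gives a number 10.5 percentage points higher from compound 2 to compound 4 (beyond the scatter), the only single-place comparison at this position. The two groups have the same heavy atom count, and cyclohexylamino adds one hydrogen-bond donor while the ring becomes carbon only. Nothing available explains the step. The compounds shown leave open whether the amine hydrogen or the ring change carries the step, a question that methyl(cyclohexyl)amino at this carbon would address. Going by these compounds, whether cyclopentylamino or anilino would behave like cyclohexylamino also remains open.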